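This account rests on a few compounds, and the source may have more. Where it says the series, first, only, none or still open, it means among the compounds named here.

Compound 1, `O=C(CCC1=CCN(CCCc2ccc(Br)cc2)C1=O)NO`: 2520 nM in a functional assay on NCI-H23 cells (Homo sapiens) for inhibition, read by sulforhodamine B assay; on this read-out lower numbers stand for stronger inhibition of growth and higher numbers for weaker inhibition of growth
Compound 2, `Cc1cccc(CN2CC=C(CCC(=O)NO)C2=O)c1`: 2500 nM in this assay
Compound 3, `O=C(CCC1=CCN(Cc2ccc(F)cc2)C1=O)NO`: 4670 nM in this assay

The three measured compounds share a core carrying a hydroxamic acid and differ only in the group hung on the lactam nitrogen. Compound 1 stands second highest of the three numbers, yet its gap to compound 2 and its gap to compound 3 both lie within the usual scatter of this assay, so nothing separates the three beyond that scatter.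

Compound 4, `CC(C)c1ccc(CCCN2CC=C(CCC(=O)NO)C2=O)cc1`, keeps the chain of compound 1 and changes the substituent on the aromatic ring: isopropyl in place of bromo on an aromatic carbon. The site is on an aromatic carbon of a six-membered aromatic ring of carbon only, para to a large group. For the measured compounds named here, no measured pair shows this exchange, and among the three compounds none of the differences in the group on the lactam nitrogen moves the number beyond the scatter. On that basis the step from compound 1 to compound 4 is expected to be small, with no direction beyond the scatter, giving a 1.0-fold higher number from compound 1 to compound 4 (0.01 log units; within the scatter). Compound 4 is therefore estimated at 2600 nM in this assay, within a range from 1100 nM to 6500 nM.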

Compound 4, concentration for 50% growth inhibition: 2520 nM
Compound 4: the middle estimate sits 1.0-fold (0.01 log units) above what was measured; the range from low to high includes it.
By their numbers in this assay, from the lowest: compounds 2, 1, 4 and 3 (each within the scatter of the next).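

In this assay, putting isopropyl in place of bromo on an aromatic carbon, para to a large group, gives no change at the digits printed from compound 1 to compound 4 (within the scatter). This is the only step shown between compounds that differ in one place, and it gives the first direct look at this position: 3 heavy atoms of carbon stand where 1 heavy atom of bromine stood, with no change in the number beyond the scatter. Nothing measured here says why the number holds, as no supporting evidence accompanies this result.

From the compounds shown here alone, both groups in this step have no hydrogen-bond donors or acceptors and no net charge, so it remains open whether an amine, a carboxylic acid or a methoxy group at this position would leave the number just as it is. Going by these compounds, it also remains open whether isopropyl and bromo would match each other on the shorter chain of compound 3, since this single step speaks only for the chain of compound 1 and compound 4.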